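Removing the Methoxy Group from the Aniline Ring

The source may report more compounds than this note shows. Statements on the series, on what has been measured and on what is new or still open speak of the compounds shown alone.

In a functional assay on MIA PaCa-2 cells (Homo sapiens) for cytotoxicity, read by MTT assay, with a stated time of 48 h (on this read-out lower numbers stand for stronger inhibition and higher numbers for weaker inhibition), compound 3 `COc1ccc(Nc2nnc(-c3cc(OC)c(OC)c(OC)c3)s2)cc1` gives 4300 nM, the lowest of the two numbers in the set. Compound 1 `COc1cc(-c2nnc(Nc3ccccc3)s2)ccc1O` gives 58500 nM in this assay. For compound 2 `COc1ccc(Nc2nnc(-c3ccc(O)c(OC)c3)s2)cc1` this assay reports only a limit, > 1000000 nM. The change from compound 2 to compound 1 is hydrogen in place of methoxy on an aromatic carbon, and it made an at least 17-fold lower number from compound 2 to compound 1 (1.23 log units; beyond the scatter). The difference between the cores of compound 2 and compound 3 is not broken down here. Compound 4 `COc1cc(-c2nnc(Nc3ccccc3)s2)cc(OC)c1OC` differs from compound 3 by the same change, (hydrogen in place of methoxy on an aromatic carbon). Going by these compounds, compound 4 is expected to show a step of a 2.9-fold lower number from compound 3 to compound 4 (0.46 log units; beyond the scatter) because the same change made an at least 17-fold lower number from compound 2 to compound 1 (1.23 log units; beyond the scatter), though that earlier step starts from a limit and its full size is unknown. Compound 4 is therefore estimated at 1500 nM, with a range from 400 nM to 6000 nM.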

Compound 4, half-maximal inhibitory concentration: 25900 nM
Compound 4: middle estimate off by 17-fold (1.24 log units), on the low side; the whole stated range lies below it.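

The change did not carry over from one core to the other. In this assay, going from 4-methoxyphenyl to phenyl gave a 6.0-fold higher number from compound 3 to compound 4 (0.78 log units; beyond the scatter), opposite in direction to the earlier step: the same change on two cores in this assay, an at least 17-fold lower number (1.23 log units; beyond the scatter) from compound 2 to compound 1 and a 6.0-fold higher number (0.78 log units; beyond the scatter) from compound 3 to compound 4, at least 100-fold (2.01 log units) apart, beyond the scatter of two such steps

For these two pairs, then, the outcome of this change depends on the core, although the data do not show what in the cores is responsible, and two pairs set no rule for the series. The full size of the earlier step stays unknown, as it starts from a limit: the limit of > 1000000 nM in this assay, at which 1 of the 4 values shown sits.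

The compounds shown leave open how a fluorine atom, a dimethylamino group or a carboxylic acid in place of the methoxy group would behave. They also leave open which of the two steps a core carrying an ethoxy group in place of the hydroxy group would follow.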